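A few compounds are considered here, and "the series" means these few. Any claim that something is new, unique, unknown or untested is made for them only; others in the source may bear on it.

Measured compounds:
compound 1, `Cc1nsc2[nH]c(SCc3ccccc3)nc12`: 9000 nM
compound 2, `c1ccc(CSc2nc3cnsc3[nH]2)cc1`: 200 nM
compound 3, `CSc1nc2c(C)nsc2n1[C@@H]1O[C@H](CO)[C@@H](O)[C@H]1O`: > 100000 nM

All three were tested in a functional assay on KB cells (Homo sapiens) for antiproliferative activity; on this read-out higher numbers stand for weaker inhibition and lower numbers for stronger inhibition. Compound 1 and compound 2 share one core and differ by a single change, (hydrogen in place of methyl on an aromatic carbon). This change gave a 45-fold lower number from compound 1 to compound 2 (1.65 log units; beyond the scatter), so compound 2 stands out clearly from compound 1 in this assay.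

Compound 3 carries a different core, and how its core differs from that of compound 1 is not broken down here. For compound 3 the result in this assay is only a limit, (the limit of > 100000 nM in this assay, at which 1 of the 3 values shown sits), not a measured number.

Compound 4, `CSc1nc2cnsc2n1[C@@H]1O[C@H](CO)[C@@H](O)[C@H]1O`, is not yet measured. It relates to compound 3 by hydrogen in place of methyl on an aromatic carbon, the same change that links compound 1 to compound 2, at the same place on the ring. The expected step is an at least 2.5-fold lower number from compound 3 to compound 4 (0.39 log units; beyond the scatter), resting on the size of a 45-fold lower number from compound 1 to compound 2 (1.65 log units; beyond the scatter), while the starting point of compound 3 being a limit leaves the outcome uncertain. Compound 4 is therefore expected to give about 40000 nM, in the range 3000 nM to 300000 nM.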

Compound 4, half-maximal inhibitory concentration: > 100000 nM
Compound 4: no number, only a limit; the forecaster's own chance of this, stated with the estimate: 50%; middle value at least 2.5-fold (0.39 log units) from the limit.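

Compound 3 and compound 4 both stop at the same limit in this assay, not at a measured number, so the step between them cannot be read: the limit of > 100000 nM in this assay, at which 2 of the 4 values shown sit.

The compounds shown leave open whether hydrogen in place of methyl changes activity at all on the core of compound 3, as it does between compound 1 and compound 2.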